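Two methoxy groups in place of one on the aryl ring

The compounds below may be only part of what the source reports. "The series", "measured", "known", "first", "only" and "open" are said of these compounds alone.

Of the compounds shown here, three of a shared core have been measured in a functional assay on microsomes for inhibition, with a stated time of 1 h; a lower number here means a stronger inhibitor, a higher number a weaker inhibitor. Compound 1 `Cn1c(NN)nc(-c2cccc(O)c2O)c(C#N)c1=O` gives 31 ug/mL. Compound 2 `CCOC(=O)c1cnn(-c2nc(-c3ccc(OC)cc3)c(C#N)c(=O)n2C)c1N` gives 68 ug/mL. Compound 3 `CSc1nc(-c2ccc(N(C)C)cc2)c(C#N)c(=O)n1C` gives 98 ug/mL. Among these three numbers compound 2 stands second highest: its nearest neighbour is compound 3, whose number lies within the usual scatter of repeated measurements, so no order between compound 2 and compound 3 can be claimed; the furthest is compound 1, whose lower number lies beyond that scatter, so compound 1 is the stronger inhibitor of the two.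

Compound 4 `CCOC(=O)c1cnn(-c2nc(-c3cccc(OC)c3OC)c(C#N)c(=O)n2C)c1N` has not yet been measured. It differs from compound 2 in one place: 2,3-dimethoxyphenyl in place of 4-methoxyphenyl on an aromatic carbon. Among the measured compounds shown here, no measured pair shows this change on its own, and compound 1, compound 2 and compound 3 each differ from one another in more than one place, so the step carries no direct precedent.

With nothing to anchor it, the step from compound 2 to compound 4 in this assay is expected to be small, leaning toward a somewhat lower number but quite possibly staying within the scatter: a 1.4-fold lower number from compound 2 to compound 4 (0.13 log units; within the scatter). Compound 4 is therefore estimated at 50 ug/mL, with a range from 22 ug/mL to 110 ug/mL.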

Compound 4, half-maximal inhibitory concentration: 57 ug/mL
Compound 4: middle estimate off by 1.1-fold (0.06 log units), on the low side; measured number inside the range.
By their numbers in this assay, from the lowest: compounds 1, 4, 2 and 3 (each within the scatter of the next, the first and the last beyond it).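

In this assay, placing 2,3-dimethoxyphenyl in place of 4-methoxyphenyl on this aromatic carbon, ortho to a cyano group and next to the ring nitrogen, gives a 1.2-fold lower number from compound 2 to compound 4 (0.08 log units; within the scatter), and this is the first pair shown that differs in only one place. The two compounds therefore cannot be told apart in this assay, so at this position, on this core, the larger 2,3-dimethoxyphenyl group, with its second oxygen, is compatible with inhibition in the same range as 4-methoxyphenyl. No separate measurement is available that would explain this outcome.

This single step alters both the number of methoxy groups and where they sit on the aryl ring, so the two alterations cannot be separated, and a 2-methoxyphenyl, a 3-methoxyphenyl or a plain phenyl group would be needed to pull them apart. Also open, from the compounds shown here alone, is whether a different kind of substituent on that ring, such as an amine or a carboxylic acid, would move the number beyond the scatter, and whether the same swap behaves alike on the cores of compound 1 and compound 3.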